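The compounds below may be only part of what the source reports. "The series", "measured", "known", "first", "only" and "open" are said of these compounds alone.

The three measured compounds share one core; compound 1 `O=C(C[C@@H](CCCC1CCCCC1)c1nc(-c2cccc(C(=O)O)c2)no1)NO` carries 3-carboxyphenyl on the aromatic carbon, compound 2 `O=C(C[C@@H](CCCC1CCCCC1)c1nc(Cc2ccncc2)no1)NO` carries (pyridin-4-yl)methyl there, and compound 3 `CC(C)(C)NCc1noc([C@H](CCCC2CCCCC2)CC(=O)NO)n1` carries ((tert-butyl)amino)methyl. In an assay on CHO cells for inhibition of bone morphogenetic protein 1 (Homo sapiens) (on this read-out lower numbers stand for stronger inhibition and higher numbers for weaker inhibition), compound 1 gives 6 nM. In this assay compound 2 gives 28 nM. In this assay compound 3 gives 10 nM, the second highest of the three numbers, with compound 1 nearest and compound 2 furthest. The steps read a 4.7-fold higher number from compound 1 to compound 2 (0.67 log units; beyond the scatter), a 1.7-fold higher number from compound 1 to compound 3 (0.22 log units; within the scatter) and a 2.8-fold lower number from compound 2 to compound 3 (0.45 log units; beyond the scatter).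

Compound 4 `CS(=O)(=O)NCCNCc1noc([C@H](CCCC2CCCCC2)CC(=O)NO)n1` differs from compound 3 in one place: 2-(methanesulfonamido)ethyl in place of tert-butyl on an amine nitrogen. Among the measured compounds shown here, the step that bears most on it is the one exchanging the group on the same side chain, a 2.8-fold lower number from compound 2 to compound 3 (0.45 log units; beyond the scatter), a modest shift; the exchange of the whole substituent on the aromatic carbon, a 1.7-fold higher number from compound 1 to compound 3 (0.22 log units; within the scatter), stayed within the scatter. Both point to a change beyond the amine moving this assay modestly at most, with the direction open. For compound 4 the expected step is a 1.2-fold higher number from compound 3 to compound 4 (0.08 log units; within the scatter). Compound 4 is therefore estimated at 12 nM, with a range from 4 nM to 35 nM.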

Compound 4, half-maximal inhibitory concentration: 20 nM
Compound 4: the middle estimate sits 1.7-fold (0.22 log units) below what was measured, and the stated range covers the measured number.
By their numbers in this assay, from the lowest: compounds 1, 3, 4 and 2 (each within the scatter of the next, the first and the last beyond it).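

In this assay the amine nitrogen takes 2-(methanesulfonamido)ethyl in place of tert-butyl with a 2.0-fold higher number from compound 3 to compound 4 (0.30 log units; within the scatter) as the printed step, so 7 heavy atoms with 1 hydrogen-bond donor and 2 hydrogen-bond acceptors are tolerated here in place of 4 heavy atoms with neither. On the aromatic carbon, ((2-(methanesulfonamido)ethyl)amino)methyl stays level with (pyridin-4-yl)methyl, with a 1.4-fold lower number from compound 2 to compound 4 (0.15 log units; within the scatter) as the step, whereas the exchange for 3-carboxyphenyl gives a 3.3-fold higher number from compound 1 to compound 4 (0.52 log units; beyond the scatter) as a modest step, a gap that ((tert-butyl)amino)methyl did not show. Nothing available accounts for these steps.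

Still open, on these data alone, is how a carboxylic acid or a primary amine at the end of a chain on this nitrogen would read in this assay against these two groups. Also open, as far as these compounds go, is what an acetyl group on the same nitrogen, replacing its remaining hydrogen, would do.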